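The compounds below may be only part of what the source reports. "The series", "measured", "known", "first", "only" and "open" are said of these compounds alone.

Compound 2 `CC1(C)CCC(C)(C)c2cc(NC(=O)c3ccc(C(=O)NCC(=O)OCc4c(-c5ccccc5)no[n+]4[O-])cc3)ccc21`: 190 nM
Compound 3 `CC1(C)CCC(C)(C)c2cc(NC(=O)c3ccc(C(=O)OCCCCCOC(=O)c4ccc(OCc5c(-c6ccccc6)no[n+]5[O-])cc4)cc3)ccc21`: 240000 nM
Compound 1 `CC1(C)CCC(C)(C)c2cc(NC(=O)c3ccc(C(=O)OCCCCCCOC(=O)c4ccc(OCc5c(-c6ccccc6)no[n+]5[O-])cc4)cc3)ccc21`: reported only as a limit, > 1000000 nM

In a functional assay on NB-4 cells (Homo sapiens) for antiproliferative activity, read by MTT assay, with a stated time of 48 h (a higher number here means a weaker inhibitor, a lower number a stronger inhibitor), compound 2 stands at the lowest of the two numbers, and compound 3 sits well above it, beyond the scatter. For compound 1 the assay gives only a limit, (the limit of > 1000000 nM in this assay, at which 1 of the 3 values shown sits), not a number.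

Compound 4 `CC(C)C[C@H](NC(=O)c1ccc(C(=O)Nc2ccc3c(c2)C(C)(C)CCC3(C)C)cc1)C(=O)OCc1c(-c2ccccc2)no[n+]1[O-]` is a close relative of compound 2: isobutyl in place of hydrogen on a saturated chain carbon bound to an amide-type nitrogen and a carbonyl carbon. Within the data shown here, no measured pair shows this kind of change, so there is no step to lean on. The change is small and adds no charge or polar group, so the expected step in this assay is none beyond the scatter, in either direction. Compound 4 is therefore estimated at 160 nM, with a range from 50 nM to 600 nM, which means an expected step of a 1.2-fold lower number from compound 2 to compound 4 (0.07 log units; within the scatter).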

Compound 4, half-maximal inhibitory concentration: 970 nM
Compound 4: the middle estimate sits 6.1-fold (0.78 log units) below what was measured, outside the stated range (above it).
By their numbers in this assay, from the lowest: compound 2; then compound 4; then compound 3. At a limit, above all of these: compound 1.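

Isobutyl in place of hydrogen on this saturated chain carbon gives a 5.1-fold higher number from compound 2 to compound 4 (0.71 log units; beyond the scatter) in this assay, so this position responds to substitution. The step is modest, but this change costs activity rather than leaving it unchanged. Nothing in the data shown accounts for this step.

From the compounds shown here alone, it remains open whether a methyl group would cost less than isobutyl on this carbon. Going by these compounds, it is also open how an amine or a carboxylic acid at the same place would compare.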